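A few compounds are considered here, and "the series" means these few. Any claim that something is new, unique, unknown or untested is made for them only; others in the source may bear on it.

Compound 1 `NC(=O)c1ccc2c(ccn2-c2ccc(NC(=O)c3cccc(C(F)(F)F)c3)cc2)n1`: > 10000 nM
Compound 2 `COC(=O)c1ccc2c(ccn2-c2ccc(NC(=O)Nc3ccc(Cl)c(Cl)c3)cc2)n1`: 3800 nM

Both compounds were tested in a functional assay on A375P cells (Homo sapiens) for cytotoxicity, read by MTT assay; on this read-out lower numbers stand for stronger inhibition and higher numbers for weaker inhibition. For compound 1 the value > 10000 nM is a limit of the assay rather than a number, and it sits at the limit of > 10000 nM in this assay, at which 1 of the 2 values shown sits. Going by the values given here, compound 2, with 3800 nM, therefore gives the only real number in this assay, and no measured step between two compounds exists to lean on.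

Compound 3 `NC(=O)c1ccc2c(ccn2-c2ccc(NC(=O)Nc3ccc(Cl)c(Cl)c3)cc2)n1` keeps the urea side of compound 2 and alters only the other end: amino in place of methoxy on a carbonyl carbon. Compound 1 also carries a carbamoyl group on the shared core, but its other end is built differently, so it cannot show what this single change does on its own.

In this assay the change from compound 2 to compound 3 is expected to be a 1.6-fold higher number from compound 2 to compound 3 (0.20 log units; within the scatter), a modest weakening if anything, and barely beyond the usual scatter. Compound 3 is estimated at 6000 nM, with a range from 1500 nM to 30000 nM, and a fair chance that only a limit is reported.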

Compound 3, half-maximal inhibitory concentration: 3200 nM
For compound 3 the middle estimate is 1.9-fold (0.27 log units) above the measured one; the range from low to high includes it.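

In this assay, putting amino in place of methoxy on a carbonyl carbon gives a 1.2-fold lower number from compound 2 to compound 3 (0.07 log units; within the scatter), so the methoxycarbonyl and carbamoyl groups cannot be told apart at this place, even though the swap gives up a hydrogen-bond acceptor and brings in a hydrogen-bond donor. Going by these compounds alone, with the carbamoyl group held fixed, the other end of the molecule does make a difference: (3,4-dichlorophenyl)amino in place of 3-(trifluoromethyl)phenyl on a carbonyl carbon gives an at least 3.1-fold lower number from compound 1 to compound 3 (0.49 log units; beyond the scatter), the first reading of a change at that end. That step has only a lower bound, since compound 1 gives > 10000 nM, which is a limit and not a number: the limit of > 10000 nM in this assay, at which 1 of the 3 values shown sits.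

On these data alone, whether a carboxylic acid, a nitrile or a longer ester such as ethoxycarbonyl would fit in with methoxycarbonyl and carbamoyl at this place remains open, so two groups are too few to call the position tolerant in general. The step at the other end also changes the aryl substituents and the amino link together, which leaves open how much of it belongs to each, and whether a single chlorine would be enough.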